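Swapping cyclopropyl for acetylpyrrolidinyl on the amide carbonyl

The source may report more compounds than this note shows. Statements on the series, on what has been measured and on what is new or still open speak of the compounds shown alone.

Measured compounds:
- Compound 1, `CC1CCCN1C1CCN(c2ccc(NC(=O)CC3CCCC3)cc2)C1`: 3.1 nM
- Compound 2, `CC(=O)N1CCCC1C(=O)Nc1ccc(N2CCC(N3CCCC3C)C2)c(C)c1`: 44.9 nM
- Compound 3, `CC1CCCN1C1CCN(c2ccc(NC(=O)C3CC3)cc2)C1`: 9.7 nM

All three share one core, differing only in the group attached to the amide carbonyl carbon. In an assay on CHO cells for displacement of a labelled ligand from histamine receptor H3 (Macaca mulatta) (on this read-out lower numbers stand for stronger inhibition and higher numbers for weaker inhibition), compound 3 gives 9.7 nM, which places it second of the three: compound 1 lies at a lower number, compound 2 at a higher one.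

Going by the values given here, the single measured step that touches this carbonyl position is a 3.1-fold higher number from compound 1 to compound 3 (0.50 log units; beyond the scatter), a modest change when a larger carbon ring is replaced by cyclopropyl.

Compound 4, `CC(=O)N1CCCC1C(=O)Nc1ccc(N2CCC(N3CCCC3C)C2)cc1`, is not yet measured. It differs from compound 3 by 1-acetylpyrrolidin-2-yl in place of cyclopropyl on a carbonyl carbon. Among the compounds with values here, no measured step mirrors this exact swap. Compound 2, however, carries the same 1-acetylpyrrolidin-2-yl group on its carbonyl carbon and gives 44.9 nM, a higher number than compound 3. On that basis compound 4 is expected to show a higher number than compound 3, a step of about a 3.1-fold higher number from compound 3 to compound 4 (0.49 log units; beyond the scatter). The estimate for compound 4 in this assay is 30 nM, with a likely range from 10 nM to 90 nM.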

Compound 4, inhibition constant: 14.1 nM
Compound 4: the middle estimate sits 2.1-fold (0.33 log units) above what was measured; measured number inside the range.
By their numbers in this assay, from the lowest: compound 1; then compounds 3 and 4 (each within the scatter of the next); then compound 2.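

In this assay, the larger 1-acetylpyrrolidin-2-yl group on the carbonyl carbon cannot be told apart from cyclopropyl (a 1.5-fold higher number from compound 3 to compound 4 (0.16 log units; within the scatter)), so this position accepts both groups. Compound 2 carries the same group, yet hydrogen in place of its methyl on an aromatic carbon gives a step beyond the scatter (a 3.2-fold lower number from compound 2 to compound 4 (0.50 log units; beyond the scatter)). Cyclopentylmethyl still gives the lowest number at this carbonyl carbon (a 4.5-fold higher number from compound 1 to compound 4 (0.66 log units; beyond the scatter)).

Going by these compounds, how an amine or a carboxylic acid on this carbonyl carbon would read remains open, as does whether the methyl on an aromatic carbon would shift the number the same way with cyclopropyl in place. Nothing shown gives a reason for any of these steps.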